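Hydroxy Returned to Compound 2: Expected Cytotoxicity of Compound 3

The source may report more compounds than this note shows. Statements on the series, on what has been measured and on what is new or still open speak of the compounds shown alone.

Compound 1, `C=C1[C@](C)(O)CC[C@@]1(C)c1ccc(C)c(O)c1`: in a functional assay on Bel-7402 cells (Homo sapiens) for cytotoxicity, read by MTT assay (on this read-out higher numbers stand for weaker inhibition and lower numbers for stronger inhibition), compound 1 gives only a limit, > 10 ug/mL.
Compound 2, `C=C1[C@](C)(O)CC[C@@]1(C)c1ccc(C)cc1`: in this assay compound 2 gives only a limit, > 10 ug/mL.

Compound 2 thus stands at a limit of this assay, not at a number. Within the data shown here, the only measured step, a step that the two limits leave unreadable from compound 1 to compound 2, is unreadable because of the limit of > 10 ug/mL in this assay, at which 2 of the 2 values shown sit. Compound 3, `C=C1[C@](C)(O)CC[C@@]1(C)c1ccc(C)cc1O`, differs from compound 2 by hydroxy in place of hydrogen on an aromatic carbon. Among the measured compounds shown here, no measured step tells the size or direction of this change, so compound 3 is expected to stay near the limit in this assay, with the step that the limit leaves unreadable from compound 2 to compound 3 estimated as none beyond the scatter. Compound 3 is estimated at 15 ug/mL, from 7 ug/mL to 40 ug/mL.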

Compound 3, half-maximal inhibitory concentration: > 10 ug/mL
Compound 3: no number, only a limit; the forecaster's own chance of this, stated with the estimate: 75%; the middle value does not contradict the limit.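

No step can be read from compound 2 to compound 3, because both values are limits and not numbers: the limit of > 10 ug/mL in this assay, at which 3 of the 3 values shown sit.

The compounds shown leave open whether hydroxy in place of hydrogen on an aromatic carbon changes the result in this assay at all.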